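A few compounds are considered here, and "the series" means these few. Any claim that something is new, unique, unknown or untested is made for them only; others in the source may bear on it.

Compound 3 (`Cc1c(C(=O)N/N=C\c2c(O)cccc2Cl)oc2cccc(O)c12`) is a hydrazone in which the aryl ring bears a 2-chloro-6-hydroxyphenyl group. In a functional assay on PC-3 cells (Homo sapiens) for inhibition (on this read-out higher numbers stand for weaker inhibition and lower numbers for stronger inhibition), compound 3 gives 18700 nM, the higher of the two numbers recorded. Compound 2 (`Cc1c(C(=O)N/N=C\c2ccccc2O)oc2cccc(O)c12`) gives 8350 nM in this assay. Compound 1 (`Cc1c(C(=O)N/N=C\c2ccccc2F)oc2cccc(O)c12`) gives only a limit in this assay, >= 40000 nM (the limit of >= 40000 nM in this assay, at which 1 of the 3 values shown sits). The steps measured so far run an at least 4.7-fold lower number from compound 1 to compound 2 (0.68 log units; beyond the scatter) and a 2.2-fold higher number from compound 2 to compound 3 (0.35 log units; beyond the scatter); the hydroxy group thus carries the larger effect, the chloro the smaller.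

Compound 4 (`Cc1c(C(=O)N/N=C\c2cccnc2)oc2cccc(O)c12`) differs from compound 3 by pyridin-3-yl in place of 2-chloro-6-hydroxyphenyl on a carbon with a double bond to nitrogen. The incoming pyridin-3-yl group keeps an acceptor but brings no donor, so the hydroxy group whose arrival gave the step of an at least 4.7-fold lower number from compound 1 to compound 2 (0.68 log units; beyond the scatter) is gone, while the chloro is gone as well. On balance a rise in this assay is expected for compound 4, of about a 1.6-fold higher number from compound 3 to compound 4 (0.21 log units; within the scatter). Compound 4 is therefore estimated at 30000 nM in this assay, within a range of 12000 nM to 80000 nM.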

Compound 4, half-maximal inhibitory concentration: >= 40000 nM
Compound 4 ended at the assay's limit; the forecaster's own chance of this, stated with the estimate: 35%; at least 1.3-fold (0.12 log units) between middle value and limit.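

The ring nitrogen of pyridin-3-yl does not stand in for the hydroxy group on this carbon with a double bond to nitrogen: the change gives an at least 2.1-fold higher number from compound 3 to compound 4 (0.33 log units; beyond the scatter) and an at least 4.7-fold higher number from compound 2 to compound 4 (0.68 log units; beyond the scatter) in this assay on both counts. Compound 4 gives >= 40000 nM and this value is a limit of the assay, so both steps are minimum sizes. So far only the two compounds with a hydroxy on the aryl ring, compound 2 and compound 3, give numbers rather than limits, and the step between compound 1 and compound 4 cannot be read: the limit of >= 40000 nM in this assay, at which 2 of the 4 values shown sit.

The compounds shown leave open whether another group in place of the hydroxy, such as an amine or a carboxylic acid, would also bring the number down from the limit. They also leave open whether compound 1 and compound 4 differ at all.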